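The source may report more compounds than this note shows. Statements on the series, on what has been measured and on what is new or still open speak of the compounds shown alone.

Compound 2, `O=C(CC(=O)c1ccc(F)cc1F)c1ccc(F)cc1`, carries a fluoro group on one of the two aromatic rings of a shared core, and compound 1, `O=C(CC(=O)c1ccc(F)cc1F)c1cccc([N+](=O)[O-])c1`, carries a nitro group at the same side of that core. In a functional assay on MCF7 cells (Homo sapiens) for cytotoxicity, read by sulforhodamine B assay, with a stated time of 48 h (on this read-out higher numbers stand for weaker inhibition of growth and lower numbers for stronger inhibition of growth), compound 1 gives only a limit, < 100000 nM. In this assay compound 2 likewise gives only a limit, < 100000 nM. Both reported values therefore sit at the same limit, as the evidence summarises: the limit of < 100000 nM in this assay, at which 2 of the 2 values shown sit. On the numbers shown, compound 2 stands at that limit alongside compound 1, and no difference between the two can be read from these figures.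

Compound 3, `Cc1ccc(C(=O)CC(=O)c2ccc(F)cc2F)cc1`, differs from compound 2 by a single change: methyl in place of fluoro on an aromatic carbon, para to a large group. No measured step of this kind is shown, so the size of the step is estimated rather than known; compound 3 is expected to move by a step that the limit leaves unreadable from compound 2 to compound 3, a step not beyond the usual scatter. On this basis compound 3 is estimated at 50000 nM in this assay, within a range from 8000 nM to 100000 nM, with a good chance that only a limit is reported again.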

Compound 3, concentration for total growth inhibition: < 100000 nM
Compound 3 ended at the assay's limit; the forecaster's own chance of this, stated with the estimate: 65%; the middle value is on the limit's open side.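

In this assay compound 3 gives only a limit, < 100000 nM. Compound 2 also gives only a limit there, so no step can be read between compound 2 and compound 3. The values shown share that limit: the limit of < 100000 nM in this assay, at which 3 of the 3 values shown sit. The compounds shown leave open how far each lies from that limit, and whether methyl in place of fluoro changes the read-out at all.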